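This account rests on a few compounds, and the source may have more. Where it says the series, first, only, none or still open, it means among the compounds named here.

Measured so far:
- compound 1 `Cc1ccc(O)c(C(O)(C(F)(F)F)C(F)(F)F)c1` — 454000 nM
- compound 2 `O=C(COc1ccc2cc(C(O)(C(F)(F)F)C(F)(F)F)c(O)cc2c1)Nc1ccccc1` — > 20000 nM
- compound 3 `CCCNC(=O)COc1ccc2cc(C(O)(C(F)(F)F)C(F)(F)F)c(O)cc2c1` — > 20000 nM

For the measured compounds named here, in an assay on isolated protein for inhibition of tyrosine-protein phosphatase non-receptor type 13 (Homo sapiens), read by spectrophotometry (on this read-out lower numbers stand for stronger inhibition and higher numbers for weaker inhibition), compound 1 gives 454000 nM, the only plain number in the set. For compound 2 the assay reports only a limit, > 20000 nM. For compound 3 the assay likewise reports only a limit, > 20000 nM. The step that the two limits leave unreadable from compound 2 to compound 3 is therefore not readable, the reason being (the limit of > 20000 nM in this assay, at which 2 of the 3 values shown sit). Compound 3 thus stands at the assay limit, and one further value of the three is also a limit.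

Compound 4 `O=C(COc1ccc2cc(C(O)(C(F)(F)F)C(F)(F)F)c(O)cc2c1)NCc1ccccc1` differs from compound 3 by phenyl in place of ethyl on a saturated chain carbon bound to an amide-type nitrogen. Going by the values given here, the only measured step that touches the amide substituent, a step that the two limits leave unreadable from compound 2 to compound 3, gives no size, and no other measured step bears on this change, so no shift beyond the scatter can be anticipated in either direction. Compound 4 is expected in this assay at 30000 nM, with a range of 8000 nM to 200000 nM, and will most probably again be reported only as a limit. The step this estimate implies is a step that the limit leaves unreadable from compound 3 to compound 4.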

Compound 4, half-maximal inhibitory concentration: > 20000 nM
Compound 4: no number, only a limit; the forecaster's own chance of this, stated with the estimate: 70%; the middle value is on the limit's open side.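

In this assay compound 4 gives > 20000 nM, again only a limit, so no step among compound 2, compound 3 and compound 4 can be read: the limit of > 20000 nM in this assay, at which 3 of the 4 values shown sit.

The compounds shown leave open whether changing the amide substituent among phenyl, propyl and benzyl alters inhibition at all.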